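The source may report more compounds than this note shows. Statements on the series, on what has been measured and on what is new or still open speak of the compounds shown alone.

Measured compounds:
- compound 1 `COc1ccc(C(=O)/C=C/c2ccc(N3CCCC3)cc2)c2c1C=CC(C)(C)O2` gives 7370 nM in a functional assay on SK-OV-3 cells (Homo sapiens) for antiproliferative activity, read by MTT assay, with a stated time of 24 h; a higher number here means a weaker inhibitor, a lower number a stronger inhibitor
- compound 2 `COc1ccc(C(=O)/C=C/c2cccc([N+](=O)[O-])c2)c2c1C=CC(C)(C)O2` gives 9720 nM in this assay
- compound 3 `COc1ccc(C(=O)/C=C/c2cccc(C(F)(F)F)c2)c2c1C=CC(C)(C)O2` gives 9330 nM in this assay

Compound 2 shows the largest number of the three, but this says little: its gap to compound 3 is a 1.0-fold lower number from compound 2 to compound 3 (0.02 log units; within the scatter), and its gap to compound 1 is also within the usual scatter, so the three compounds are not separable on these numbers.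

Compound 4 `COc1ccc(C(=O)/C=C/c2cc(Cl)ccc2O)c2c1C=CC(C)(C)O2` is the next compound to be measured in this assay. It differs from compound 2 as follows: 5-chloro-2-hydroxyphenyl in place of 3-nitrophenyl on a double-bonded chain carbon bound to a double-bonded chain carbon

Among the compounds with values here, the only measured step that bears on this change is the one from compound 2 to compound 3, which swapped one substituent on the aryl ring for another and gave a 1.0-fold lower number from compound 2 to compound 3 (0.02 log units; within the scatter). Within the data shown here, no measured pair covers a hydroxyl or a chlorine on that ring, so there is nothing to suggest a shift beyond the scatter. The step from compound 2 to compound 4 is therefore estimated at a 1.1-fold lower number from compound 2 to compound 4 (0.03 log units; within the scatter). For compound 4 the expected value is 9000 nM, with a range from 4000 nM to 20000 nM.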

Compound 4, half-maximal inhibitory concentration: 6270 nM
Compound 4: middle estimate off by 1.4-fold (0.16 log units), on the high side; measured number inside the range.
By their numbers in this assay, from the lowest: compounds 4, 1, 3 and 2 (each within the scatter of the next).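

Placing 5-chloro-2-hydroxyphenyl in place of 3-nitrophenyl on this double-bonded chain carbon gives, in this assay, a 1.6-fold lower number from compound 2 to compound 4 (0.19 log units; within the scatter) and so stays inside the scatter. This reaches further than the earlier step, a 1.0-fold lower number from compound 2 to compound 3 (0.02 log units; within the scatter), which exchanged one substituent for another on the ring: here the whole aryl group changes, and a hydrogen-bond donor and a chlorine enter, yet the compounds remain inseparable on these numbers. No available data explain the size of this step.

The separate contributions of hydroxyl and chlorine stay unresolved, since no compound shown carries only one of them. As far as these compounds go, it also remains open whether a carboxylic acid, a primary amine or a longer alkoxy chain on this ring would produce a step beyond the scatter.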